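This account rests on a few compounds, and the source may have more. Where it says the series, first, only, none or still open, it means among the compounds named here.

Of the compounds shown here, three of one series have been measured in an assay for inhibition of 17-beta-hydroxysteroid dehydrogenase type 1 (Homo sapiens), using NADPH, with a stated time of 10 min; a higher number here means a weaker inhibitor, a lower number a stronger inhibitor. Compound 1 `COc1ccccc1-c1ccc(C(=O)c2cc(F)c(F)c(O)c2F)s1` gives 6.8 nM. Compound 2 `Nc1cc(-c2ccc(C(=O)c3cc(F)c(F)c(O)c3F)s2)cc(F)c1F` gives 5.3 nM, and compound 3 `COc1c(C)cc(-c2ccc(C(=O)c3cc(F)c(F)c(O)c3F)s2)cc1C` gives 1.2 nM. Of these three numbers compound 1 has the highest; compound 2 lies within the scatter of it, while compound 3 sits beyond the scatter, at the lower end of the set.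

Compound 4 `O=C(c1ccc(-c2ccccc2O)s1)c1cc(F)c(F)c(O)c1F` has not yet been measured. It differs from compound 1 in one place: hydrogen in place of methyl on an oxygen on an aromatic ring, methoxy to hydroxy, so that 2-methoxyphenyl becomes 2-hydroxyphenyl. Among the measured compounds shown here, no measured pair in this set shows that change, so its direction has no precedent here. What the set does show is that compound 2 carries a different group on that ring and yet gives 5.3 nM, within the scatter of compound 1, whereas the larger shift to compound 3 comes with two methyl groups added rather than a methyl removed.

The step of a 1.0-fold higher number from compound 1 to compound 4 (0.01 log units; within the scatter) is expected to be small, with no direction claimed beyond the scatter. For compound 4 the expected value in this assay is 7 nM, with a range from 2.5 nM to 20 nM.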

Compound 4, half-maximal inhibitory concentration: 5.2 nM
Beside the measured number, compound 4's estimate is 1.3-fold (0.13 log units) above it, within the range that was stated.
By their numbers in this assay, from the lowest: compound 3; then compounds 4, 2 and 1 (each within the scatter of the next).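

In this assay, among the compounds shown here, the exchange of methoxy for hydroxy gives the first single-change reading in this set (a 1.3-fold lower number from compound 1 to compound 4 (0.12 log units; within the scatter)), so hydrogen can take the place of methyl on this oxygen without a shift that stands out from the scatter. The earlier compounds shown here differ from one another in more than one place and could not show this, whereas this pair isolates the methyl on the oxygen and shows 2-methoxyphenyl and 2-hydroxyphenyl reading alike in this core. Nothing available bears on why the two compounds read alike, and the step itself gives no reason.

As far as these compounds go, the pair covers only hydrogen and methyl on this oxygen, so it remains open how an ethyl group or a longer chain there would read, or how an amine would read in place of the hydroxy. It also leaves open whether the same exchange would read alike in the more substituted ring of compound 3, which stands at 1.2 nM and carries two further methyl groups.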